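Swapping the imide ring on a weak nicotinic antagonist

The source may hold more compounds than are shown below. What is called first, only, known or untested is meant among the compounds shown, and "the series" means these compounds.

Of the compounds shown here, three have been tested in an in vitro functional assay on HEK ts201 cells for antagonist activity at Neuronal acetylcholine receptor; alpha4/beta2 (Homo sapiens), read by fluorescence and calcium flux; a lower number here means a stronger inhibitor, a higher number a weaker inhibitor. Compound 1 `CC1CC(=O)N(c2ccccc2C(=O)CCC2CCCN(CCCCOc3ccc(C(F)(F)F)cc3)C2)C1=O` gives 7080 nM. Compound 2 `CC1(C)CC(=O)N(c2ccccc2C(=O)OCC2CCCN(CCCc3ccccc3)C2)C1=O` gives 4900 nM, the lowest of the three numbers, though compound 1 sits within the scatter of it, so no order between those two can be read. Compound 3 `O=C(CCc1ccccc1)N1CCCC(CN(Cc2ccccc2-c2ccccc2)Cc2ccccc2-c2ccccc2)C1` gives 20900 nM, a number that lies beyond the scatter from compound 2. All three are weak inhibitors on this scale.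

The piece follows the step from compound 2 to compound 4 `O=C(OCC1CCCN(CCCc2ccccc2)C1)c1ccccc1N1C(=O)c2ccccc2C1=O`, which has not yet been measured in this assay. The change is a group of 11 heavy atoms (8 carbon, 1 nitrogen, 2 oxygen; one five-membered non-aromatic ring with 1 hetero atom, one six-membered aromatic ring of carbon only) in place of a group of 9 heavy atoms (6 carbon, 1 nitrogen, 2 oxygen; one five-membered non-aromatic ring with 1 hetero atom), on an aromatic carbon. In plainer terms, the small five-membered imide ring of compound 2 keeps its two carbonyls, but its two methyl groups give way to a fused benzene ring, and the rest of the molecule is untouched.

Going by the values given here, no pair of measured compounds differs in this place alone, so there is no measured step to lean on; compounds 1 to 3 each differ from one another in several places at once. With a change of this size, a step of a 1.1-fold lower number from compound 2 to compound 4 (0.04 log units; within the scatter) is expected, which is to say no shift beyond the usual scatter is expected in either direction. Compound 4 is thus expected to give about 4500 nM, with a range from 1500 nM to 14000 nM.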

Compound 4, half-maximal inhibitory concentration: 5010 nM
For compound 4 the middle estimate is 1.1-fold (0.05 log units) below the measured one; the measured number falls inside the stated range.
By their numbers in this assay, from the lowest: compounds 2, 4 and 1 (each within the scatter of the next); then compound 3.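

In this assay, replacing the 3,3-dimethyl-2,5-dioxopyrrolidin-1-yl group with the larger group carrying a fused benzene ring gives a 1.0-fold higher number from compound 2 to compound 4 (0.01 log units; within the scatter). Going by these compounds alone, this is the first measured step at this aromatic carbon, which the earlier compounds could not provide, as they differed from one another in several places at once; it shows that, on this molecule, the two imide groups cannot be told apart by this read-out, even though one carries an extra aromatic ring. Nothing measured here accounts for this result or shows how the added ring is accommodated.

From the compounds shown here alone, both groups tested at this position keep the two carbonyls on a five-membered ring, so it remains open whether a group without that ring, such as a plain amine or a carboxylic acid, would give a number clearly apart from these two. Going by these compounds, it is also open whether the same exchange would give a similar result with a different chain on the ring nitrogen, such as the 4-(trifluoromethyl)phenoxybutyl chain of compound 1.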